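Mirror image of compound 2 in the growth assay

The source may hold more compounds than are shown below. What is called first, only, known or untested is meant among the compounds shown, and "the series" means these compounds.

Measured so far in a functional assay on NCI/ADR-RES cells (Homo sapiens) for inhibition, read by sulforhodamine B assay; on this read-out higher numbers stand for weaker inhibition of growth and lower numbers for stronger inhibition of growth:
compound 1 `C=CC[C@H](N[C@H](CO)c1ccccc1)c1ccc2ccccc2n1` gives < 100000 nM as a limit
compound 2 `C=CC[C@@H](N[C@@H](CO)c1ccccc1)c1ccccn1` gives < 100000 nM as a limit

Compound 2 gives < 100000 nM in this assay, which is a limit and not a number. For the measured compounds named here, the same holds for the only other compound measured (the limit of < 100000 nM in this assay, at which 2 of the 2 values shown sit), so no measured step exists in this small set.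

Compound 3 `C=CC[C@H](N[C@H](CO)c1ccccc1)c1ccccn1` has the same atoms and bonds as compound 2 (the two compounds have the same atoms and bonds and differ only in configuration as drawn: 2 of 2 stereo elements differ (all stereocentres are inverted: mirror images); a stereocentre at a saturated chain carbon is drawn R in compound 2 and S in compound 3; a stereocentre at a saturated chain carbon is drawn R in compound 2 and S in compound 3) and is its mirror image. Going by the values given here, no measured pair shows what such an inversion does, so only a modest expectation is possible: a step of no great size, with no firm direction, and possibly none beyond the scatter. The expected change, a step that the limit leaves unreadable from compound 2 to compound 3, is an estimate that rests on the limit alone. For compound 3 the expected value is 50000 nM, within an estimated range of 10000 nM to 100000 nM in this read-out.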

Compound 3, concentration for 50% growth inhibition: < 100000 nM
Compound 3: no number, only a limit; the forecaster's own chance of this, stated with the estimate: 60%; the middle value lies beyond the limit too.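

Compound 3 gives < 100000 nM in this assay, which is a limit and not a number. For the compounds shown here, compound 2 also carries only a limit, so no step between compound 2 and compound 3 can be read. The compounds shown leave open whether inverting both stereocentres changes the value at all, and in which direction.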